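Replacing Methylamino with Morpholinyl on the Amide Carbonyl

This account rests on a few compounds, and the source may have more. Where it says the series, first, only, none or still open, it means among the compounds named here.

For the measured compounds named here, compound 1 `CNC(=O)CC1CCc2cc(OC)c(OC)cc21` was tested in a functional assay on the whole organism (strain Wistar) for inhibition, with Rattus norvegicus as the target, read by paw edema, with stated times of 60 min and 24 h, at a dose of 100 mg/kg by the oral route (a higher number here means more inhibition at the dose given (going by the name of the read-out), a lower number less inhibition), where compound 1 gives 33.3%, the lower of the two numbers measured so far. Compound 2 `COc1cc2c(cc1OC)C(CC(=O)N1CCNCC1)CC2` differs only at the carbonyl carbon, and in this assay compound 2 gives 65%; the step of a number 31.7 percentage points higher from compound 1 to compound 2 (beyond the scatter) is large. Compound 3 `COc1cc2c(cc1OC)C(CC(=O)N1CCOCC1)CC2` carries a related change: morpholin-4-yl in place of methylamino on a carbonyl carbon. Going by the values given here, the only measured step bearing on it is the one to compound 2, which likewise put a six-membered ring on that carbonyl carbon, so a rise in this assay is expected, though its size is uncertain. The step of a number 16.7 percentage points higher from compound 1 to compound 3 (beyond the scatter) is the expected change. Compound 3 is estimated at 50%, within 30% to 70%.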

Compound 3, a percentage reported as inhibition, in the whole organism at one dose (the size of the read-out at that dose, not a potency): 23.3%
Compound 3: middle estimate off by 26.7 percentage points, on the high side; measured number below the stated range.
By their numbers in this assay, from the lowest: compounds 3 and 1 (each within the scatter of the next); then compound 2.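

In this assay, putting a six-membered ring on the carbonyl carbon does not by itself bring the gain seen with piperazin-1-yl: morpholin-4-yl in place of methylamino gives a step within the scatter (a number 10 percentage points lower from compound 1 to compound 3 (within the scatter)). Morpholin-4-yl in place of piperazin-1-yl gives a large step (a number 41.7 percentage points lower from compound 2 to compound 3 (beyond the scatter)), so what matters among these three compounds is which ring sits there, not merely that a ring does. Nothing at hand explains this difference.

Going by these compounds, whether the gain depends on the second ring nitrogen of piperazin-1-yl stays open. A piperidin-1-yl or 4-methylpiperazin-1-yl group on the same carbonyl carbon would bear on that question.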